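A Chlorophenyl Variant in a Series Without Readable Steps

The source may hold more compounds than are shown below. What is called first, only, known or untested is meant among the compounds shown, and "the series" means these compounds.

Compound 3 `O=C(/C=C\c1ccc(F)cc1)N1N=C(c2ccncc2)OC1c1c[nH]c2ccccc12` carries a 4-fluorophenyl on a double-bonded chain carbon of the shared core. In an ADME assay on A549 cells (Homo sapiens) for cytotoxicity, read by MTT assay, with a stated time of 48 h (a higher number here means a weaker inhibitor of growth, a lower number a stronger inhibitor of growth), compound 3 gives only a limit, > 30 ug/mL. The two other measured compounds behave the same way. Compound 1 `O=C(/C=C\c1ccccc1[N+](=O)[O-])N1N=C(c2ccncc2)OC1c1c[nH]c2ccccc12`, with a 2-nitrophenyl in that place, gives in this assay a limit of > 30 ug/mL. Compound 2 `O=C(/C=C\c1cccc(F)c1)N1N=C(c2ccncc2)OC1c1c[nH]c2ccccc12`, with a 3-fluorophenyl there, gives in this assay a limit of > 30 ug/mL. All three values sit at the limit of > 30 ug/mL in this assay, at which 3 of the 3 values shown sit, so the steps connecting them cannot be sized: a step that the two limits leave unreadable from compound 1 to compound 2, a step that the two limits leave unreadable from compound 1 to compound 3 and a step that the two limits leave unreadable from compound 2 to compound 3.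

Compound 4 `O=C(/C=C\c1ccccc1Cl)N1N=C(c2ccncc2)OC1c1c[nH]c2ccccc12` differs from compound 3 in that (2-chlorophenyl in place of 4-fluorophenyl on a double-bonded chain carbon bound to a double-bonded chain carbon). Going by the values given here, the steps that bear on this change are the two aryl exchanges ending at compound 3, and both are unreadable because every value involved rests at the limit of > 30 ug/mL in this assay, at which 3 of the 3 values shown sit. Nothing in these data suggests that exchanging one substituted phenyl for another moves the result off the limit, so the step from compound 3 to compound 4 is expected to be a step that the limit leaves unreadable from compound 3 to compound 4, that is, none beyond the scatter. In this assay compound 4 is therefore estimated at 45 ug/mL, within a range from 25 ug/mL to 100 ug/mL, most likely reported again only as a limit.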

Compound 4, concentration for 50% growth inhibition: > 30 ug/mL
Compound 4 ended at the assay's limit (the forecaster's own chance of this, stated with the estimate: 80%); the middle value does not contradict the limit.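

Compound 4 gives only a limit in this assay, and so do compound 1, compound 2 and compound 3, so no step from any of them to compound 4 can be read: the limit of > 30 ug/mL in this assay, at which 4 of the 4 values shown sit.

The compounds shown leave open how far these four compounds truly lie from one another, and whether any aryl exchange at this place would move a value off the limit.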